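A few compounds are considered here, and "the series" means these few. Any claim that something is new, unique, unknown or untested is made for them only; others in the source may bear on it.

Among the measured compounds shown here, in a functional assay on MCF7 cells (Homo sapiens) for inhibition, read by sulforhodamine B assay, with a stated time of 48 h, tested at 50 uM (on this read-out lower numbers stand for less inhibition of growth and higher numbers for more inhibition of growth at the one concentration tested), compound 1 (`COc1ccc([C@@H]2C/C(=N/OCc3cn(-c4ccc(C#N)cc4)nn3)c3cc(CC=C(C)C)c(OC)cc3O2)cc1`) gives 40%, the lower of the two numbers so far, and compound 2 (`CCOc1ccc([C@@H]2CC(=O)c3cc(CC=C(C)C)c(OC)cc3O2)cc1`) gives 57%, a gap beyond the scatter. Compound 3 (`COc1ccc([C@@H]2C/C(=N/OCc3cn(-c4ccc(C(N)=O)cc4)nn3)c3cc(CC=C(C)C)c(OC)cc3O2)cc1`) has not yet been measured. It keeps the core of compound 1 but carries carbamoyl in place of cyano on an aromatic carbon, para to a large group: carbamoyl in place of cyano on an aromatic carbon. For the measured compounds named here, no measured pair shows such a change, so no step beyond the scatter is expected in this assay. The estimated step is a number 2 percentage points lower from compound 1 to compound 3 (within the scatter). Compound 3 is expected to give 38%, within an estimated range from 22% to 55%.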

Compound 3, percent growth inhibition at one concentration: 100%
Compound 3: middle estimate off by 62 percentage points, on the low side, outside the stated range (above it).
By their numbers in this assay, from the lowest: compound 1; then compound 2; then compound 3.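

In this assay, carbamoyl in place of cyano on an aromatic carbon, para to a large group, gives a number 60 percentage points higher from compound 1 to compound 3 (beyond the scatter) with the rest of the structure unchanged. Among the compounds shown here, this shows that the position is not indifferent in this assay, which no earlier pair could show. The change adds a hydrogen-bond donor and an oxygen, but nothing measured here tells what lies behind the step. On these data alone, it remains open whether a carboxylic acid, a methyl ester or an amine at this position would give a similar number, and whether the step would hold on another core.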